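The source may hold more compounds than are shown below. What is called first, only, known or untested is meant among the compounds shown, and "the series" means these compounds.

The measured compounds:
compound 1, `O=C(CCC(=O)OCCCCCCSc1ccc([N+](=O)[O-])c2nonc12)Nc1ccccc1F`, gives 4270 nM in an ADME assay on L02 cells (Homo sapiens) for cytotoxicity, read by MTT assay, with a stated time of 72 h; a higher number here means a weaker inhibitor, a lower number a stronger inhibitor
compound 2, `COc1ccccc1NC(=O)CCC(=O)OCCCCCCSc1ccc([N+](=O)[O-])c2nonc12`, gives 4490 nM
compound 3, `O=C(CCC(=O)OCCCCCCSc1ccc([N+](=O)[O-])c2nonc12)NCCN1CCCC1`, gives 6580 nM

Compound 1 has the lowest of the three numbers, yet the gap to compound 2 is a 1.1-fold higher number from compound 1 to compound 2 (0.02 log units; within the scatter) and the gap to compound 3 is a 1.5-fold higher number from compound 1 to compound 3 (0.19 log units; within the scatter), so the three cannot be told apart on this evidence. Compound 4, `O=C(CCC(=O)N1CCOCC1)OCCCCCCSc1ccc([N+](=O)[O-])c2nonc12`, has not been measured. It differs from compound 1 in one place: morpholin-4-yl in place of (2-fluorophenyl)amino on a carbonyl carbon. Going by the values given here, the step that bears most on this is the one from compound 1 to compound 3, a 1.5-fold higher number from compound 1 to compound 3 (0.19 log units; within the scatter), where 2-(pyrrolidin-1-yl)ethyl took the place of 2-fluorophenyl on an amide-type nitrogen, a swap of a ring of carbon only for a non-aromatic group carrying a nitrogen. The step from compound 2 to compound 3, a 1.5-fold higher number from compound 2 to compound 3 (0.17 log units; within the scatter), shows the same. Neither left the scatter, so no step beyond the scatter is expected in this assay for compound 4. Compound 4 is therefore estimated at 5500 nM, with a range from 2500 nM to 12000 nM. That estimate amounts to an expected step of a 1.3-fold higher number from compound 1 to compound 4 (0.11 log units; within the scatter).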

Compound 4, half-maximal inhibitory concentration: 3240 nM
Compound 4: the middle estimate sits 1.7-fold (0.23 log units) above what was measured, and the stated range covers the measured number.
By their numbers in this assay, from the lowest: compounds 4, 1, 2 and 3 (each within the scatter of the next, the first and the last beyond it).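

At this carbonyl carbon, morpholin-4-yl is the first group shown without an amide hydrogen, yet in this assay replacing the aryl amino groups gives a 1.3-fold lower number from compound 1 to compound 4 (0.12 log units; within the scatter) and a 1.4-fold lower number from compound 2 to compound 4 (0.14 log units; within the scatter), so removing that hydrogen brings no step beyond the scatter in these two pairs. Going by these compounds alone, replacing the (2-(pyrrolidin-1-yl)ethyl)amino group gives a 2.0-fold lower number from compound 3 to compound 4 (0.31 log units; beyond the scatter), the first step in this set to pass the scatter, so the change at this position can be told apart from the scatter, though only modestly. No measurement is available to explain this step. The compounds shown leave open how a piperidin-1-yl group, a dimethylamino group or a carboxylic acid on this carbonyl carbon would compare. They also leave open whether a longer chain on the ester oxygen would change the number.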